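The compounds below may be only part of what the source reports. "The series", "measured", "known", "first", "only" and "open" are said of these compounds alone.

In a functional assay on MIA PaCa-2 cells (Homo sapiens) for inhibition, read by MTT assay, with a stated time of 72 h, tested at 50 uM (on this read-out lower numbers stand for less inhibition of growth and higher numbers for more inhibition of growth at the one concentration tested), three compounds have been measured so far. Compound 1 `C=CCc1ccc(OCc2cn(-c3cccc([N+](=O)[O-])c3)nn2)c(O)c1` gives 58.8%, compound 3 `C=CCc1ccc(OCc2cn(-c3cccc(C#N)c3)nn2)c(O)c1` gives 41.6%, and compound 2 `C=CCc1cc(O)c(O)c(CN2CCC(C)CC2)c1` gives 90.6%. Compound 2 therefore stands highest of the three, clearly beyond the scatter from both of the others.

The next compound is compound 4 `C=CCc1cc(O)c(O)c(CN2CCC(CO)CC2)c1`, which differs from compound 2 by a single change: hydroxy in place of hydrogen on a saturated chain carbon bound to a saturated ring carbon. This places hydroxy in place of hydrogen on a saturated chain carbon bound to a saturated ring carbon, turning methyl into hydroxymethyl.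

For the measured compounds named here, only one measured step is available, a number 17.2 percentage points lower from compound 1 to compound 3 (beyond the scatter), with cyano in place of nitro on an aromatic carbon. It is a different change at a different place, so it bears on the question only loosely. Going by the values given here, it shows that one small replacement can move this read-out beyond the scatter, but no measured pair tests the new hydroxy. Compound 2, at 90.6%, also leaves little room for a rise, so a modest fall seems more likely than a gain.

The expected step is a number 10.6 percentage points lower from compound 2 to compound 4 (beyond the scatter). For compound 4, the estimated value is 80%, with an expected range from 60% to 97%.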

Compound 4, percent growth inhibition at one concentration: 38.6%
For compound 4 the middle estimate is 41.4 percentage points above the measured one; the whole stated range lies above it.
By their numbers in this assay, from the lowest: compounds 4 and 3 (each within the scatter of the next); then compound 1; then compound 2.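

In this assay, adding one hydroxy to the saturated chain carbon bound to a saturated ring carbon, which turns methyl into hydroxymethyl, gives a number 52 percentage points lower from compound 2 to compound 4 (beyond the scatter). For the compounds shown here, this is the first measured pair to test this position, and it shows that the place is far from indifferent: a single added oxygen atom, bringing one hydrogen-bond donor and one hydrogen-bond acceptor by count, is enough to remove much of the growth inhibition seen at the one concentration tested. Nothing measured here explains why the hydroxy has so large an effect at this position.

The compounds shown leave open whether this fall belongs to the hydroxy itself or would follow from other replacements of the methyl, such as an ethyl, a methoxymethyl, an aminomethyl or a carboxylic acid, each of which would help separate the effect of the oxygen from that of a longer substituent. They also leave open whether the same step would hold at other concentrations, since this read-out gives a single point for each compound.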